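Swapping the Ethoxyphenyl Amide for a Nitrophenyl Amide

This account rests on a few compounds, and the source may have more. Where it says the series, first, only, none or still open, it means among the compounds named here.

Compound 1 `O=C(COc1ccc2c(=O)ccoc2c1)Nc1cccc(NC(=O)c2ccccc2)c1` gives 16 nM in an assay on isolated protein for inhibition of Rho-associated protein kinase 2 (Homo sapiens), read by scintillation counting, radiometric assay and 33P incorporation, with a stated time of 40 min, in the presence of a further agent that is not named here; on this read-out lower numbers stand for stronger inhibition and higher numbers for weaker inhibition.
Compound 2 `O=C(COc1ccc2c(=O)ccoc2c1)Nc1cccc(NC(=O)c2ccc(F)cc2)c1` gives 54 nM in this assay.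
Compound 3 `CCOc1ccc(C(=O)Nc2cccc(NC(=O)COc3ccc4c(=O)ccoc4c3)c2)cc1` gives 9 nM in this assay.

All three compounds share one core and differ only in what sits on the outer benzamide ring. Compound 3 has the lowest number of the three, but the gap to compound 1 is within the scatter, so the two cannot be ranked; only compound 2 stands clearly apart, as a 6.0-fold lower number from compound 2 to compound 3 (0.78 log units; beyond the scatter) shows. The measured steps are a 3.4-fold higher number from compound 1 to compound 2 (0.53 log units; beyond the scatter) and a 1.8-fold lower number from compound 1 to compound 3 (0.25 log units; within the scatter).

Compound 4 `O=C(COc1ccc2c(=O)ccoc2c1)Nc1cccc(NC(=O)c2cccc([N+](=O)[O-])c2)c1` is the next step: 3-nitrophenyl in place of 4-ethoxyphenyl on a carbonyl carbon. Every measured step changes the same ring, so all bear on it, yet none brings in a nitro group, and the closest lesson is that a small substituent gave a higher number in a 3.4-fold higher number from compound 1 to compound 2 (0.53 log units; beyond the scatter). A modest rise is therefore expected, about a 3.3-fold higher number from compound 3 to compound 4 (0.52 log units; beyond the scatter), with wide uncertainty. Compound 4 is estimated at 30 nM, in a range from 8 nM to 120 nM.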

Compound 4, half-maximal inhibitory concentration: 41 nM
For compound 4 the middle estimate is 1.4-fold (0.14 log units) below the measured one; measured number inside the range.
By their numbers in this assay, from the lowest: compounds 3 and 1 (each within the scatter of the next); then compounds 4 and 2 (each within the scatter of the next).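

In this assay, 3-nitrophenyl in place of 4-ethoxyphenyl on the carbonyl carbon gives a 4.6-fold higher number from compound 3 to compound 4 (0.66 log units; beyond the scatter), and nitro in place of hydrogen gives a 2.6-fold higher number from compound 1 to compound 4 (0.41 log units; beyond the scatter), so this ring accepts a nitro group at a measurable cost in inhibition. Set against the fluorinated amide, the nitro amide cannot be told apart, at a 1.3-fold lower number from compound 2 to compound 4 (0.12 log units; within the scatter), which means that two different substituents both raise the number over the unsubstituted ring, while the ethoxy group of compound 3 goes against that trend. Nothing available here explains these differences.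

This step changes both the group and its place on the ring, so a 4-nitrophenyl or a 3-ethoxyphenyl amide would be needed to separate the two. Going by these compounds, how an amine, a carboxylic acid or a chain longer than ethoxy would behave on this ring also remains open.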